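Swapping the anilino aryl group of compound 1

The compounds below may be only part of what the source reports. "The series", "measured", "known", "first", "only" and "open" are said of these compounds alone.

This account follows a single structural change made to compound 1 `CCS(=O)(=O)Nc1cc(-c2ccc3ncnc(Nc4ccc(OC(F)(F)F)cc4)c3c2)cnc1OC`. In a functional assay on BT-549 cells (Homo sapiens) for cytotoxicity, read by sulforhodamine B assay, with a stated time of 72 h (on this read-out higher numbers stand for weaker inhibition and lower numbers for stronger inhibition), compound 1 gives 8240 nM, which places it second highest of the three numbers recorded. Compound 2 `CCS(=O)(=O)Nc1cc(-c2ccc3ncnc(Nc4ccc(Cl)c(C(=O)OC)c4)c3c2)cnc1OC` gives 2360 nM in this assay, and the step of a 3.5-fold lower number from compound 1 to compound 2 (0.54 log units; beyond the scatter) shows that exchanging the group on the nitrogen on the aromatic ring can move the read-out by a modest amount. Compound 3 `CCCCS(=O)(=O)Nc1cc(-c2ccc3ncnc(Nc4ccc(F)c(Cl)c4)c3c2)cnc1OC` gives 56800 nM, but it differs from compound 1 in two places, so its value alone says nothing about either change by itself.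

Compound 4 `CCS(=O)(=O)Nc1cc(-c2ccc3ncnc(Nc4ccc(OC)nc4)c3c2)cnc1OC` is built from compound 1 by the change (6-methoxypyridin-3-yl in place of 4-(trifluoromethoxy)phenyl on a nitrogen on an aromatic ring). Going by the values given here, only the step from compound 1 to compound 2 bears on this position, and it was modest. Among the compounds with values here, the data hold no other example of this particular replacement. Compound 4 is therefore expected to stay near compound 1, with the step of a 1.2-fold higher number from compound 1 to compound 4 (0.08 log units; within the scatter) expected to lie within the scatter. Compound 4 is estimated at 10000 nM, with a range from 3000 nM to 33000 nM.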

Compound 4, half-maximal inhibitory concentration: 3490 nM
Compound 4: middle estimate off by 2.9-fold (0.46 log units), on the high side; low and high end bracket the measured number.
By their numbers in this assay, from the lowest: compounds 2 and 4 (each within the scatter of the next); then compound 1; then compound 3.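

The second replacement on this nitrogen lowers the number as well, a 2.4-fold lower number from compound 1 to compound 4 (0.37 log units; beyond the scatter), so the step seen with compound 2 is no longer a single case. The two replacing groups are quite different, one a 4-chloro-3-(methoxycarbonyl)phenyl and the other a 6-methoxypyridin-3-yl, yet the step of a 1.5-fold higher number from compound 2 to compound 4 (0.17 log units; within the scatter) lies within the scatter, and the data do not separate them. No measurement on these compounds accounts for either step.

The compounds shown cannot tell whether the methoxy group or the ring nitrogen of compound 4 carries the step, which a plain pyridinyl or a methoxyphenyl group on the same nitrogen would help to separate. Going by these compounds, how a carboxylic acid or an amine on the aryl ring would read also remains open.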